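A few compounds are considered here, and "the series" means these few. Any claim that something is new, unique, unknown or untested is made for them only; others in the source may bear on it.

Measured so far in an assay on isolated protein for inhibition of Amine oxidase [flavin-containing] A (Homo sapiens), read by fluorescence, with a stated time of 20 min; a lower number here means a stronger inhibitor, a higher number a weaker inhibitor:

compound 1, `CC/C(C)=N\Nc1nc(-c2cccc([N+](=O)[O-])c2)cs1`: 20500 nM
compound 2, `CCCC/C(C)=N\Nc1nc(-c2cccc([N+](=O)[O-])c2)cs1`: 6330 nM
compound 3, `CCC/C(CC)=N\Nc1nc(-c2cccc([N+](=O)[O-])c2)cs1`: 4860 nM

In this assay, among the measured compounds shown here, the step of a 3.2-fold lower number from compound 1 to compound 2 (0.51 log units; beyond the scatter) is the only change between a shared core and a directly comparable pair; the change itself is ethyl in place of hydrogen on a saturated chain carbon, two bonds along the chain from a carbon with a double bond to nitrogen. Compound 3 sits at the low end of the three numbers, but the nearest step is a 1.3-fold lower number from compound 2 to compound 3 (0.11 log units; within the scatter), so no order between compound 2 and compound 3 is claimed. Against compound 1 the step is a 4.2-fold lower number from compound 1 to compound 3 (0.63 log units; beyond the scatter), and the cores of compound 1 and compound 3 differ as a group of 7 heavy atoms (6 carbon, 1 nitrogen; no ring) in place of a group of 5 heavy atoms (4 carbon, 1 nitrogen; no ring), on a nitrogen on an aromatic ring.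

Compound 4, `CCCCC/C(CC)=N\Nc1nc(-c2cccc([N+](=O)[O-])c2)cs1`, is not yet measured. It differs from compound 3 as ethyl in place of hydrogen on a saturated chain carbon, three bonds along the chain from a carbon with a double bond to nitrogen. This is the same kind of change as that from compound 1 to compound 2, not the same: in the earlier pair the entering ethyl stands two bonds along the chain from a carbon with a double bond to nitrogen, here it stands three bonds along. With one earlier example only, the expectation rests on compound 1 and compound 2 giving a 3.2-fold lower number from compound 1 to compound 2 (0.51 log units; beyond the scatter), and on compound 3 already standing at 4860 nM. A step of similar direction but uncertain size is expected, a 1.9-fold lower number from compound 3 to compound 4 (0.29 log units; within the scatter). Compound 4 is therefore estimated at 2500 nM, with a range from 1100 nM to 6000 nM.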

Compound 4, half-maximal inhibitory concentration: 7150 nM
Beside the measured number, compound 4's estimate is 2.9-fold (0.46 log units) below it; the measured number lies above the stated range.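

In this assay, the change of hydrogen to ethyl does not carry from one core to the other as a fixed step, and the two cases differ by more than the scatter: the same change on two cores in this assay, a 3.2-fold lower number (0.51 log units; beyond the scatter) from compound 1 to compound 2 and a 1.5-fold higher number (0.17 log units; within the scatter) from compound 3 to compound 4, 4.8-fold (0.68 log units) apart, beyond the scatter of two such steps. Among the compounds shown here, the new step, a 1.5-fold higher number from compound 3 to compound 4 (0.17 log units; within the scatter), sets no order on that pair, whereas a 3.2-fold lower number from compound 1 to compound 2 (0.51 log units; beyond the scatter) does, so a gain seen on the core of compound 1 cannot be assumed on the core of compound 3. This does not show what separates the two cases: the entering ethyl stands two bonds along the chain in one pair and three bonds along in the other, and the cores differ as well, so with a single pair of each, neither the place of the ethyl nor the core can be singled out.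

For the compounds shown here, open is how a longer chain, or a branched chain, would behave on either side of the carbon with a double bond to nitrogen, with only one pair available for each place of the ethyl. Also open, as far as these compounds go, is whether a chain ending in an amine or a carboxylic acid, or a cyclohexyl ring in place of the open chains, would follow either step.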